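Ester analogues on a naphthyl pyridine core

The compounds below may be only part of what the source reports. "The series", "measured", "known", "first", "only" and "open" are said of these compounds alone.

Measured compounds:
- compound 1, `NNC(=O)CCc1ccncc1-c1ccc2ccccc2c1`: 7.7 nM
- compound 2, `COC(=O)COc1ccncc1-c1ccc2ccccc2c1`: "not determined" (no result reported)

In an assay on a protein complex for inhibition of CDK8/Cyclin C (Homo sapiens), with a stated time of 1 h (a lower number here means a stronger inhibitor, a higher number a weaker inhibitor), compound 1 gives 7.7 nM, a strong inhibitor. Compound 2 carries a (methoxycarbonyl)methoxy group on the shared core, and in this assay compound 2 has no single number: the result is "not determined" (no result reported), so there is nothing to place it against compound 1.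

Compound 3, `COC(=O)CCc1ccncc1-c1ccc2ccccc2c1`, differs from compound 2 in one place: 2-(methoxycarbonyl)ethyl in place of (methoxycarbonyl)methoxy on an aromatic carbon. The change keeps the same count of heavy atoms but swaps one oxygen for a carbon and drops one hydrogen-bond acceptor.

Among the compounds with values here, no measured step exists for this change, and compound 2 itself gives no anchor, so the expected step in this assay from compound 2 to compound 3 cannot be stated from the data; the expectation is of no difference beyond the usual scatter. Compound 3 is estimated at 40 nM, with a range from 8 nM to 300 nM.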

Compound 3, half-maximal inhibitory concentration: 259 nM
Estimate against measurement, compound 3: 6.5-fold (0.81 log units) below; measured number inside the range.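

In this assay, the group on the carbonyl carbon clearly matters: with the rest of the molecule unchanged, putting methoxy in place of aminoamino gives a 34-fold higher number from compound 1 to compound 3 (1.53 log units; beyond the scatter) and takes a strong inhibitor to a much weaker one. Within the data shown here, this is the only comparison that can be read here, and it concerns the carbonyl carbon, not the atom that joins the chain to the aromatic ring; compound 2 has no number, so the step from it to compound 3, which exchanges (methoxycarbonyl)methoxy for 2-(methoxycarbonyl)ethyl, cannot be read. Nothing available gives a reason for the size of the step between the two measured compounds.

The compounds shown do not say whether the aminoamino group is unusual in keeping the number low, or whether a simple amide or a carboxylic acid on the same carbonyl carbon would give a similar value. They also leave open how a shorter or longer chain, or an oxygen-linked chain carrying the aminoamino group, would behave on this aromatic carbon.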